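The compounds below may be only part of what the source reports. "The series", "measured", "known", "first", "only" and "open" are said of these compounds alone.

Measured in a functional assay on UACC-62 cells (Homo sapiens) for inhibition, read by sulforhodamine B assay, with a stated time of 48 h; on this read-out higher numbers stand for weaker inhibition of growth and lower numbers for stronger inhibition of growth:
compound 1, `COc1cc(-c2nn(-c3cccc(NC(=O)Nc4cc(C(F)(F)F)cc(C(F)(F)F)c4)c3)cc2-c2ccncc2)ccc1Cl`, gives 661 nM;
compound 2, `O=C(Nc1cccc(-n2cc(-c3ccncc3)c(-c3ccc(Cl)c(O)c3)n2)c1)Nc1cc(C(F)(F)F)cc(C(F)(F)F)c1`, gives 749 nM;
compound 3, `COc1cc(-c2nn(-c3cccc(NC(=O)Nc4ccc(Cl)c(C(F)(F)F)c4)c3)cc2-c2ccncc2)ccc1Cl`, gives 737 nM.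

Compound 1 and compound 2 differ in one place: hydrogen in place of methyl on an oxygen on an aromatic ring. The step this change made in this assay was a 1.1-fold higher number from compound 1 to compound 2 (0.05 log units; within the scatter), so the two numbers are indistinguishable within the usual scatter. Compound 3 carries a different urea partner; the difference between its core and that of compound 1 is not broken down here. Compound 4, `O=C(Nc1cccc(-n2cc(-c3ccncc3)c(-c3ccc(Cl)c(O)c3)n2)c1)Nc1ccc(Cl)c(C(F)(F)F)c1`, is not yet measured and differs from compound 3 by the same change: hydrogen in place of methyl on an oxygen on an aromatic ring. Because that change gave a 1.1-fold higher number from compound 1 to compound 2 (0.05 log units; within the scatter), the expected step is similar, a 1.1-fold higher number from compound 3 to compound 4 (0.04 log units; within the scatter), essentially no movement. Compound 4 is therefore estimated at 800 nM, with a likely range from 400 nM to 1600 nM.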

Compound 4, concentration for 50% growth inhibition: 627 nM
Estimate against measurement, compound 4: 1.3-fold (0.11 log units) above; measured number inside the range.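

In this assay, replacing methoxy with hydroxy on the 4-chloro-3-methoxyphenyl group gave a 1.2-fold lower number from compound 3 to compound 4 (0.07 log units; within the scatter), a step too small to separate from the ordinary variation between repeat measurements. Set beside the earlier step, this one does not differ from it: the same change on two cores in this assay, a 1.1-fold higher number (0.05 log units; within the scatter) from compound 1 to compound 2 and a 1.2-fold lower number (0.07 log units; within the scatter) from compound 3 to compound 4, 1.3-fold (0.12 log units) apart, within the scatter of two such steps. The change therefore carries over between these two cores as no detectable shift in growth inhibition, but this does not show how it would behave on any other core or in any other assay.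

The compounds shown leave open what a longer chain on that oxygen, such as ethyl, would do. They also leave open the effect of an amine in place of the hydroxy.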